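A few compounds are considered here, and "the series" means these few. Any claim that something is new, unique, unknown or untested is made for them only; others in the source may bear on it.

Compound 1 `CCOC1=C(/C(C)=N/OCC(=O)Nc2cccc(OC)c2)N(C)S(=O)(=O)c2ccccc21` is the reference point of the set. In a functional assay on THP-1 cells (Homo sapiens) for inhibition, read by ELISA, with stated times of 2 h and 48 h (on this read-out lower numbers stand for stronger inhibition and higher numbers for weaker inhibition), compound 1 gives only a limit, > 20000 nM. Compound 2 `CCOC1=C(/C(C)=N/OCC(=O)Nc2ccc(OC)cc2)N(C)S(=O)(=O)c2ccccc21` carries 4-methoxyphenyl in place of 3-methoxyphenyl on an amide-type nitrogen. In this assay compound 2 likewise gives a limit, > 20000 nM. That change yields a step that the two limits leave unreadable from compound 1 to compound 2. Compound 3 `COc1cccc(NC(=O)CO/N=C(\C)C2=C(O)c3ccccc3S(=O)(=O)N2C)c1` differs from compound 1 in the core, hydrogen in place of ethyl on an oxygen on an unsaturated carbon. In this assay compound 3 also returns a limit, > 20000 nM. The core change therefore reads a step that the two limits leave unreadable from compound 1 to compound 3. Within the data shown here, every value so far sits at the limit of > 20000 nM in this assay, at which 3 of the 3 values shown sit, so nothing has yet been resolved as a number.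

Compound 4 `COc1ccc(NC(=O)CO/N=C(\C)C2=C(O)c3ccccc3S(=O)(=O)N2C)cc1`, not yet measured, differs from compound 3 by 4-methoxyphenyl in place of 3-methoxyphenyl on an amide-type nitrogen; the place is worded identically for the earlier pair, so this is the same change as from compound 1 to compound 2. The expected step from compound 3 to compound 4 is a step that the limit leaves unreadable from compound 3 to compound 4, resting on the earlier pair having shown a step that the two limits leave unreadable from compound 1 to compound 2. Compound 4 is therefore estimated at 30000 nM, with an expected span from 10000 nM to 100000 nM, most probably reported again only as a limit.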

Compound 4, half-maximal inhibitory concentration: > 20000 nM
Compound 4 was reported as a limit (the forecaster's own chance of this, stated with the estimate: 80%); the middle value does not contradict the limit.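

In this assay compound 4 gives > 20000 nM, a limit and not a number, so the steps to compound 4 from compound 3 and from compound 2 cannot be read. The compounds shown leave open whether either change, on the amide-type nitrogen or on the oxygen of the shared core, alters inhibition at all, and the series rests on a single reported limit: the limit of > 20000 nM in this assay, at which 4 of the 4 values shown sit.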